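The source may hold more compounds than are shown below. What is called first, only, known or untested is meant among the compounds shown, and "the series" means these compounds.

Within the data shown here, compound 1 `O=C(O)CN1C(=O)[C@@H](NC(=O)[C@@H](S)Cc2ccccc2)COc2ccccc21` gives 3.1 nM in an assay on isolated protein for inhibition of Neprilysin (Homo sapiens) (on this read-out lower numbers stand for stronger inhibition and higher numbers for weaker inhibition), the highest of the three numbers measured so far. Compound 2 `O=C(O)CN1C(=O)[C@@H](NC(=O)[C@@H](CS)Cc2ccccc2)COc2ccccc21` gives 0.6 nM, and compound 3 `O=C(O)CCN1C(=O)[C@@H](NC(=O)[C@@H](S)Cc2ccccc2)CSc2ccccc21` gives 2.2 nM in this assay; compound 3 differs from compound 1 in two places, so that pair shows only its two values, which lie within the scatter of each other. The single-site step measured, a 5.2-fold lower number from compound 1 to compound 2 (0.71 log units; beyond the scatter), concerns the sulfanyl group and not the acid chain. Compound 4 `O=C(O)CCN1C(=O)[C@@H](NC(=O)[C@@H](S)Cc2ccccc2)COc2ccccc21` carries carboxymethyl in place of carboxy on a saturated chain carbon bound to an amide-type nitrogen in a ring. Among the measured compounds shown here, no measured step bears on that change directly, so no step beyond the scatter is expected. The expected step is a 1.2-fold lower number from compound 1 to compound 4 (0.09 log units; within the scatter). Compound 4 is therefore estimated at 2.5 nM, within a range of 0.9 nM to 7 nM.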

Compound 4, half-maximal inhibitory concentration: 1.2 nM
Compound 4: the middle estimate sits 2.1-fold (0.32 log units) above what was measured, within the range that was stated.
By their numbers in this assay, from the lowest: compounds 2, 4, 3 and 1 (each within the scatter of the next, the first and the last beyond it).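

Extending the acid chain from carboxy to carboxymethyl, on a saturated chain carbon bound to an amide-type nitrogen in a ring, gives a 2.6-fold lower number from compound 1 to compound 4 (0.41 log units; beyond the scatter) in this assay. The acid chain is thus a second place where one change moves the number beyond the scatter, which the earlier step, on the sulfanyl group, could not show. Nothing at hand explains this step. Still open, as far as these compounds go, is how a longer carboxylic acid chain, or an amine in place of the acid, would read, and whether the step holds alongside the sulfanylmethyl group of compound 2.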